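From Amide to Acid on the Shared Core

The compounds below may be only part of what the source reports. "The series", "measured", "known", "first", "only" and "open" are said of these compounds alone.

In a physicochemical assay for lipophilicity, read by HPLC, at pH 7.5 (on this read-out higher numbers stand for higher lipophilicity and lower numbers for lower lipophilicity), compound 1 (`CCOc1ccccc1-c1ccc(-c2nc3cnccc3cc2C#N)cc1`) gives 3.8, compound 2 (`CC[C@@H](Nc1c(C#N)c(-c2ccc(-c3cccc(Cl)c3F)cc2)nc2cnccc12)C(=O)O`) gives 2.2, and compound 3 (`CCOc1ccccc1-c1ccc(-c2nc3cnccc3c(N[C@H](CC)C(N)=O)c2C#N)cc1`) gives 3. Compound 3 is therefore the second highest of the three, with compound 1 above it and compound 2 below it, each gap lying beyond the scatter.

Compound 4 (`CCOc1ccccc1-c1ccc(-c2nc3cnccc3c(N[C@H](CC)C(=O)O)c2C#N)cc1`) departs from compound 3 in one place: hydroxy in place of amino on a carbonyl carbon. This is hydroxy in place of amino on a carbonyl carbon, which reads as carbamoyl to carboxy.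

For the measured compounds named here, the one measured step, a number 0.80 log units lower from compound 1 to compound 3 (beyond the scatter), comes from placing (1-carbamoylpropyl)amino where hydrogen stood on an aromatic carbon. Going by the values given here, it is a different change, so it sets no direct size for this swap, and no measured pair shows carbamoyl going to carboxy. Among the compounds with values here, the closest guide is compound 2, the only measured compound bearing (1-carboxypropyl)amino, although it differs from compound 4 elsewhere in the structure. The value of compound 2, 2.2, points to a lower number in this assay. The expected change is a number 0.90 log units lower from compound 3 to compound 4 (beyond the scatter), a drop beyond the scatter. For compound 4 the estimated value is 2.1, with an expected range from 1.5 to 2.7.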

Compound 4, distribution coefficient: 2.1
Estimate against measurement, compound 4: no gap at the digits printed, and the stated range covers the measured number.
By their numbers in this assay, from the lowest: compounds 4 and 2 (each within the scatter of the next); then compound 3; then compound 1.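

On the carbonyl carbon, hydroxy in place of amino gives a number 0.90 log units lower from compound 3 to compound 4 (beyond the scatter) in this assay, and this is the only pair shown that isolates carbamoyl to carboxy on the shared core. The same position can now be read with both groups, as (1-carbamoylpropyl)amino in place of hydrogen on an aromatic carbon gives a number 0.80 log units lower from compound 1 to compound 3 (beyond the scatter) while (1-carboxypropyl)amino in the same place gives the larger a number 1.70 log units lower from compound 1 to compound 4 (beyond the scatter) in this read-out. For the compounds shown here, with (1-carboxypropyl)amino in place in both compounds, 2-ethoxyphenyl in place of 3-chloro-2-fluorophenyl on an aromatic carbon gives a number 0.10 log units lower from compound 2 to compound 4 (within the scatter), so these two compounds cannot be told apart in this assay, a comparison that the earlier compounds could not offer.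

The compounds shown leave open where a methyl ester in place of the carboxy group, or a longer chain in place of 1-carboxypropyl, would fall relative to compound 3 and compound 4. Nothing measured in the material shown accounts for the size of these steps.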